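Swapping the carbamoyl of compound 1 for a hydroxymethyl

The source may hold more compounds than are shown below. What is called first, only, known or untested is meant among the compounds shown, and "the series" means these compounds.

Compound 1 `Cc1cc(/C=C/C#N)cc(C)c1Oc1cc(Nc2ccc(C#N)cc2)c(N)cc1C(N)=O` is the more soluble of the two measured compounds in a physicochemical assay for solubility, with a stated time of 4 h, at pH 7.4 (a higher number here means a more soluble compound, a lower number a less soluble compound), giving 0.63 ug/mL. Compound 2 `Cc1cc(CCC#N)cc(C)c1Oc1cc(Nc2ccc(C#N)cc2)c(N)cc1C(N)=O` gives 0.06 ug/mL in this assay, a step of an 11-fold lower number from compound 1 to compound 2 (1.02 log units; beyond the scatter) that changes the 2-cyanoethenyl group only. Compound 3 `Cc1cc(/C=C/C#N)cc(C)c1Oc1cc(Nc2ccc(C#N)cc2)c(N)cc1CO` differs from compound 1 elsewhere: hydroxymethyl in place of carbamoyl on an aromatic carbon. For the measured compounds named here, no measured step touches this position, so the single known step offers no direct guide, and a step of a 1.6-fold higher number from compound 1 to compound 3 (0.20 log units; within the scatter) is expected with low confidence. Compound 3 is estimated at 1 ug/mL, within 0.3 ug/mL to 3 ug/mL.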

Compound 3, solubility: 3.23 ug/mL
Estimate against measurement, compound 3: 3.2-fold (0.51 log units) below; measured number above the stated range.
By their numbers in this assay, from the lowest: compound 2; then compound 1; then compound 3.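

In this assay hydroxymethyl in place of carbamoyl on an aromatic carbon brings a 5.1-fold higher number from compound 1 to compound 3 (0.71 log units; beyond the scatter) and so shows that this position, too, can move the number beyond the scatter, not only the 2-cyanoethenyl group. The change removes one heavy atom, while each group counts one hydrogen-bond donor and one hydrogen-bond acceptor. Nothing measured here explains the rise.

Still open, going by these compounds, is whether the same swap would raise the number on the 2-cyanoethyl chain of compound 2. How a carboxylic acid or an aminomethyl group would read at this position is also unknown.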